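A few compounds are considered here, and "the series" means these few. Any claim that something is new, unique, unknown or untested is made for them only; others in the source may bear on it.

Three compounds sharing one core, which differ only in the chain bound to an oxygen on an aromatic ring, were tested in a functional assay on RAW264.7 cells (Mus musculus) for inhibition, read by Griess assay, with stated times of 1 h and 24 h (on this read-out lower numbers stand for stronger inhibition and higher numbers for weaker inhibition), and gave clear numbers. Compound 1 `CCCOc1ccccc1C1CC(=O)c2ccccc2O1` gives 46000 nM there, compound 2 `CC(C)COc1ccccc1C1CC(=O)c2ccccc2O1` gives 36700 nM there, and compound 3 `C=CCOc1ccccc1C1CC(=O)c2ccccc2O1` gives 37800 nM there. Compound 3 therefore stands level with the other two, as all three numbers lie within the scatter of one another.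

Compound 4 `CC(C)=CCOc1ccccc1C1CC(=O)c2ccccc2O1` has not yet been measured. It carries 2-methylprop-1-en-1-yl in place of vinyl on a saturated chain carbon bound to an oxygen on an aromatic ring. The same difference can be read as allyl giving way to 3-methylbut-2-en-1-yl.

Among the measured compounds shown here, three measured steps bear on this change. Methyl in place of hydrogen on the chain gave a 1.3-fold lower number from compound 1 to compound 2 (0.10 log units; within the scatter) and vinyl in place of ethyl gave a 1.2-fold lower number from compound 1 to compound 3 (0.09 log units; within the scatter) while vinyl in place of isopropyl gave a 1.0-fold higher number from compound 2 to compound 3 (0.01 log units; within the scatter) as well. For the measured compounds named here, none of them is the same change as the one in compound 4, but none moved the number beyond the scatter.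

No step beyond the scatter is therefore expected, and the estimate is a 1.1-fold lower number from compound 3 to compound 4 (0.06 log units; within the scatter) in this assay for now. Compound 4 is thus expected at 33000 nM within a range from 17000 nM to 60000 nM on this estimate.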

Compound 4, half-maximal inhibitory concentration: 32700 nM
The estimate for compound 4 lay 1.0-fold (0.00 log units) above the measured number, and the stated range covers the measured number.
By their numbers in this assay, from the lowest: compounds 4, 2, 3 and 1 (each within the scatter of the next).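

In this assay, 2-methylprop-1-en-1-yl in place of vinyl on a saturated chain carbon bound to an oxygen on an aromatic ring gives a 1.2-fold lower number from compound 3 to compound 4 (0.06 log units; within the scatter), so this larger group does not separate from the smaller one. Against the two saturated chains, the same group gives a 1.1-fold lower number from compound 2 to compound 4 (0.05 log units; within the scatter) and a 1.4-fold lower number from compound 1 to compound 4 (0.15 log units; within the scatter), which extends the earlier picture: across these four compounds, the chain can carry a double bond or not, and can be branched or not, without any step leaving the scatter, and no compound among them goes against this. Nothing measured here offers a reason why these chains read alike.

The compounds shown leave open whether a chain ending in an amine or a carboxylic acid, a benzyl group, or a much longer chain would move the number beyond the scatter at this place. They also leave open what a change elsewhere on the shared core would do, as all four compounds differ only in this one chain.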